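The source may report more compounds than this note shows. Statements on the series, on what has been measured and on what is new or still open speak of the compounds shown alone.

In a functional assay (on this read-out lower numbers stand for stronger inhibition and higher numbers for weaker inhibition), compound 1 `CC(C)=CCOc1ccc2c(c1)OC(c1cccc(F)c1)CC2=O` gives 4280 nM, compound 2 `CC(C)=CCOc1ccc2c(c1)OC(c1cccc(Cl)c1)CC2=O` gives 6300 nM and compound 3 `CC(C)=CCOc1ccc2c(c1)OC(c1ccc(Cl)cc1Cl)CC2=O` gives 5260 nM. Compound 3 thus lies within the usual scatter of both others. Compound 4 `CC(C)=CCOc1ccc2c(c1)OC(c1ccc(C)cc1)CC2=O` keeps the shared core and changes one group: 4-methylphenyl in place of 2,4-dichlorophenyl on a saturated ring carbon, next to the ring oxygen. The closest measured evidence comes from changes to the same group, a 1.2-fold higher number from compound 1 to compound 3 (0.09 log units; within the scatter) and a 1.2-fold lower number from compound 2 to compound 3 (0.08 log units; within the scatter), while chloro in place of fluoro gives a 1.5-fold higher number from compound 1 to compound 2 (0.17 log units; within the scatter). All three stay within the scatter, although none of these compounds carries 4-methylphenyl. The expected change is a 1.1-fold lower number from compound 3 to compound 4 (0.02 log units; within the scatter), so no step beyond the scatter is expected in this assay. For compound 4 the estimated value is 5000 nM, with an expected range from 2500 nM to 10000 nM.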

Compound 4, half-maximal inhibitory concentration: 4440 nM
The estimate for compound 4 lay 1.1-fold (0.05 log units) above the measured number, and the stated range covers the measured number.
By their numbers in this assay, from the lowest: compounds 1, 4, 3 and 2 (each within the scatter of the next).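

In this assay, for the compounds shown here, the saturated ring carbon next to the ring oxygen accepts 4-methylphenyl, the first group here without a halogen, and all three new steps stay within the scatter: a 1.2-fold lower number from compound 3 to compound 4 (0.07 log units; within the scatter), a 1.4-fold lower number from compound 2 to compound 4 (0.15 log units; within the scatter) and a 1.0-fold higher number from compound 1 to compound 4 (0.02 log units; within the scatter). All four aryl groups shown at this position therefore give numbers within the scatter of one another, so replacing chlorine or fluorine with a methyl group opens no measurable gap. No measurement shown offers an explanation for this flat result. On these data alone, it remains open whether an amine or a carboxylic acid on this phenyl ring, or a longer chain in its place, would move the number beyond the scatter.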